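Amide nitrogen substituent in the chromone acrylamide series

A few compounds are considered here, and "the series" means these few. Any claim that something is new, unique, unknown or untested is made for them only; others in the source may bear on it.

Compound 1 `COc1ccc2c(=O)c(/C=C/C(=O)Nc3ccccc3)coc2c1` carries a phenyl group on the amide-type nitrogen. Among the compounds with values here, in a functional assay on A549 cells (Homo sapiens) for inhibition, read by MTT assay, with a stated time of 48 h (on this read-out lower numbers stand for stronger inhibition and higher numbers for weaker inhibition), compound 1 gives 51000 nM, the highest of the three numbers measured so far. Compound 2 `COc1ccc(CNC(=O)/C=C/c2coc3cc(OC)ccc3c2=O)cc1` gives 22500 nM and compound 3 `Cc1ccc(CNC(=O)/C=C/c2coc3cc(O)ccc3c2=O)cc1` gives 17400 nM; the pair of compound 2 and compound 3 differ in two places, so only their two values are compared, not a single step.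

The change to compound 4 `COc1ccc2c(=O)c(/C=C/C(=O)NCc3ccccc3F)coc2c1` is 2-fluorobenzyl in place of phenyl on an amide-type nitrogen. Within the data shown here, the one measured step that bears on it is a 2.3-fold lower number from compound 1 to compound 2 (0.36 log units; beyond the scatter), where a benzyl-type group likewise replaced phenyl on the amide-type nitrogen. That step was modest but beyond the scatter, and compound 3, also bearing a benzyl-type group, sits lower still. A step of similar size and direction is therefore expected for compound 4, with the substituent on the ring itself differing from compound 2; the expected step is a 2.0-fold lower number from compound 1 to compound 4 (0.31 log units; beyond the scatter).

For compound 4 the estimate in this assay is 25000 nM, with a range from 12000 nM to 52000 nM.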

Compound 4, half-maximal inhibitory concentration: > 100000 nM
Compound 4: a limit, no number; the forecaster's own chance of this, stated with the estimate: 5%; middle value at least 4.0-fold (0.60 log units) away from the limit.
By their numbers in this assay, from the lowest: compounds 3 and 2 (each within the scatter of the next); then compound 1. At a limit, above all of these: compound 4.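

The reading for compound 4 in this assay is a limit of the assay and not a number: the limit of > 100000 nM in this assay, at which 1 of the 4 values shown sits.

A benzyl-type group on the amide-type nitrogen therefore does not reliably lower the number, as compound 4 goes against compound 2: the comparison with phenyl gives an at least 1.9-fold higher number from compound 1 to compound 4 (0.29 log units; that floor lies within the scatter), so even the direction of this change is not settled by its floor. Within the data shown here, the substituent on the benzyl ring carries more weight than the earlier compounds showed, with an at least 4.4-fold higher number from compound 2 to compound 4 (0.64 log units; beyond the scatter).

On these data alone, how far compound 4 lies beyond its limit remains open. Also open, as far as these compounds go, is whether the loss follows fluorine itself or the 2-fluoro pattern, a question that unsubstituted benzyl and 4-fluorobenzyl on the same nitrogen would address.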